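The source may hold more compounds than are shown below. What is called first, only, known or untested is meant among the compounds shown, and "the series" means these compounds.

Among the measured compounds shown here, compound 2 `O=C1/C(=C/c2cccc(Cl)c2)CCc2cc(O)ccc21` gives 1750 nM in a functional assay on RAW264.7 cells (Mus musculus) for inhibition (a lower number here means a stronger inhibitor, a higher number a weaker inhibitor), and the only other number measured, that of compound 1 `O=C1/C(=C/c2cccc(F)c2)CCc2cc(O)ccc21` at 1230 nM, lies within the scatter of it. Compound 3 `O=C1/C(=C/c2cccc(Br)c2)CCc2cc(O)ccc21` differs from compound 2 by bromo in place of chloro on an aromatic carbon. For the measured compounds named here, the one step that bears on this change is the earlier halogen swap, a 1.4-fold higher number from compound 1 to compound 2 (0.15 log units; within the scatter), which stayed within the scatter. The expected step of a 1.1-fold higher number from compound 2 to compound 3 (0.06 log units; within the scatter) is therefore also no change beyond the scatter. Compound 3 is estimated at 2000 nM in this assay, with a range from 1000 nM to 4000 nM.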

Compound 3, half-maximal inhibitory concentration: 1140 nM
Compound 3: middle estimate off by 1.8-fold (0.24 log units), on the high side; the range from low to high includes it.
By their numbers in this assay, from the lowest: compounds 3, 1 and 2 (each within the scatter of the next).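

In this assay bromo in place of chloro gives a 1.5-fold lower number from compound 2 to compound 3 (0.19 log units; within the scatter) and bromo in place of fluoro gives a 1.1-fold lower number from compound 1 to compound 3 (0.03 log units; within the scatter) on the same aromatic carbon. All three halogens shown at this position now stand within the scatter of one another, so this assay does not separate them here. No measurement given here accounts for this result. The compounds shown leave open whether a group other than a halogen, such as an amine, a carboxylic acid or a methoxy group, would move the number beyond the scatter at this position.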